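The source may hold more compounds than are shown below. What is called first, only, known or untested is meant among the compounds shown, and "the series" means these compounds.

Compound 2, `CCN1CCN(c2nc(N)nc3c2ncn3CCCN2CCCC2)CC1`, carries an ethyl group on the ring amine nitrogen of its six-membered ring with two nitrogens, and a free amine on its shared core. In an assay on HEK293 cells for antagonist activity at Toll-like receptor 9 (Homo sapiens), read by spectrophotometry (a lower number here means a stronger inhibitor, a higher number a weaker inhibitor), compound 2 gives 190 nM, which is the higher of the two numbers recorded so far. Its nearest neighbour is compound 1, `Fc1ccc(CNc2nc(N3CCN(C4CCCC4)CC3)c3ncn(CCCN4CCCC4)c3n2)cc1`, which differs in more than one place: it bears a cyclopentyl group on the ring amine and a fluorobenzylamino group on the core instead of the free amine. In this assay compound 1 gives 100 nM, a number that sits within the usual scatter of the number for compound 2, so the two cannot be ranked against each other.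

Compound 3, `Nc1nc(N2CCN(C3CCCC3)CC2)c2ncn(CCCN3CCCC3)c2n1`, is compound 2 with a single alteration: cyclopentyl in place of ethyl on an amine nitrogen in a ring. Among the compounds with values here, no measured pair shows this change on its own. From the two numbers in hand, the step from compound 2 to compound 3 is expected to be a 1.5-fold lower number from compound 2 to compound 3 (0.16 log units; within the scatter) in this assay, at most a modest move toward a lower number and possibly none beyond the scatter. Compound 3 is therefore estimated at 130 nM, within a range from 50 nM to 350 nM.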

Compound 3, half-maximal inhibitory concentration: 120 nM
For compound 3 the middle estimate is 1.1-fold (0.03 log units) above the measured one; the range from low to high includes it.
By their numbers in this assay, from the lowest: compounds 1, 3 and 2 (each within the scatter of the next).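

Within the data shown here, compound 3 supplies the first reading of a single change on the amine nitrogen in the six-membered ring: with cyclopentyl in place of ethyl, this assay shows a 1.6-fold lower number from compound 2 to compound 3 (0.20 log units; within the scatter), so these two groups are not told apart at this position. Among these compounds, it also supplies the first reading of a single change on the nitrogen on an aromatic ring: with hydrogen in place of 4-fluorobenzyl, this assay shows a 1.2-fold higher number from compound 1 to compound 3 (0.08 log units; within the scatter), so neither change moves the number beyond the scatter. Nothing on hand bears on these results.

The compounds shown leave open whether any group on the ring amine nitrogen would separate itself from ethyl and cyclopentyl, since a bare hydrogen, a benzyl group and a chain ending in a carboxylic acid do not appear there. They also leave open whether the nitrogen on the shared core responds to anything other than hydrogen and 4-fluorobenzyl, such as an acetyl group or a longer alkyl chain.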